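Chloro to methoxy on a triazine positive allosteric modulator series

The compounds below may be only part of what the source reports. "The series", "measured", "known", "first", "only" and "open" are said of these compounds alone.

Measured compounds:
compound 1, `Nc1nc(NCc2ccccc2)nc(-c2ccc(Cl)cc2CO)n1`: 4.76
compound 2, `Nc1nc(NCc2ccccc2)nc(-c2cc(Cl)ccc2CO)n1`: 4.49
compound 3, `COc1ccc(-c2nc(N)nc(NCc3ccccc3)n2)c(CO)c1`: 4.12

Three compounds were measured in a functional assay on cells for positive allosteric modulation of G-protein coupled receptor 68 (Homo sapiens), read by a luciferase reporter and cAMP accumulation, with a stated time of 30 min, at pH 6.8 and pH 8.3, in the presence of a further agent that is not named here; a lower number here means a less potent compound, a higher number a more potent compound, by a factor of ten per unit of this negative logarithm. Compound 1 and compound 2 are built from the same atoms joined differently; the difference between the two cores is not broken down here, and their values lie within the scatter of each other. Compound 3 arises from compound 1 by methoxy in place of chloro on an aromatic carbon, and this change gave a number 0.64 log units lower from compound 1 to compound 3 (beyond the scatter).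

Compound 4, `COc1ccc(CO)c(-c2nc(N)nc(NCc3ccccc3)n2)c1`, has not yet been measured. It arises from compound 2 by methoxy in place of chloro on an aromatic carbon. The surroundings differ: in compound 3 the methoxy sits meta to a hydroxymethyl group and para to a large group, whereas in compound 4 it sits meta to a large group and para to a hydroxymethyl group, so this is the same kind of change, not the same one.

Resting on the step seen from compound 1 to compound 3, a number 0.64 log units lower from compound 1 to compound 3 (beyond the scatter), a step of about a number 0.59 log units lower from compound 2 to compound 4 (beyond the scatter) is expected from compound 2 to compound 4 in this assay. Compound 4 is therefore estimated at 3.9, with a likely range from 3.4 to 4.5.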

Compound 4, negative logarithm of the antagonist equilibrium constant: 3.99
The estimate for compound 4 lay 0.09 log units below the measured number; measured number inside the range.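

In this assay, methoxy in place of chloro on an aromatic carbon gave a number 0.50 log units lower from compound 2 to compound 4 (beyond the scatter), so the loss seen on the core of compound 1 appeared again on the core of compound 2. Set side by side, the two steps cannot be told apart, and the change carried over from one core to the other with much the same size: the same change on two cores in this assay, a number 0.64 log units lower (beyond the scatter) from compound 1 to compound 3 and a number 0.50 log units lower (beyond the scatter) from compound 2 to compound 4, 0.14 log units apart, within the scatter of two such steps. Going by these compounds alone, this agreement rests on only two pairs in a single assay, however, and it does not show that the step would keep its size on any other core or explain why the change lowers the number.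

On these data alone, both pairs exchange chloro for methoxy alone, so it remains open whether a fluoro group, a nitrile or an amine on the same aromatic carbon would give a similar step. As far as these compounds go, it also remains open whether the step would persist if a carboxylic acid or a longer chain stood in place of the hydroxymethyl group.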